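Swapping nitro for amino on a quinoline sulfonamide

The compounds below may be only part of what the source reports. "The series", "measured", "known", "first", "only" and "open" are said of these compounds alone.

Three sulfonamides have been tested in an assay on OCI-Ly3 cells for activation of NF-kappa-B inhibitor alpha (Homo sapiens), read by a luciferase reporter; a higher number here means that more compound is needed for the effect, a lower number that less compound is needed. Compound 1 `COc1cc(NS(=O)(=O)c2ccc(C)cc2[N+](=O)[O-])c2ncccc2c1` gives 7600 nM in this assay. Compound 2 `Cc1ccc2cccc(NS(=O)(=O)c3cc([N+](=O)[O-])ccc3C)c2n1` reaches only the limit of this assay, > 57000 nM. Compound 3 `COc1cc(NS(=O)(=O)c2ccc(C)cc2[N+](=O)[O-])c2nc(C)ccc2c1` likewise reaches only the limit of this assay, > 57000 nM. Among the compounds with values here, the single change of a methyl in place of hydrogen on an aromatic carbon produced an at least 7.5-fold higher number from compound 1 to compound 3 (0.87 log units; beyond the scatter). Going by these compounds, compound 3 therefore stands at the limit of > 57000 nM in this assay, at which 2 of the 3 values shown sit, so its true number is unknown.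

Compound 4 `COc1cc(NS(=O)(=O)c2ccc(C)cc2N)c2nc(C)ccc2c1` has not yet been measured. It differs from compound 3 by amino in place of nitro on an aromatic carbon. Within the data shown here, no measured step covers this kind of change; the one step available, from compound 1 to compound 3, alters a different part of the molecule. With nothing to lean on, compound 4 is expected to show a step that the limit leaves unreadable from compound 3 to compound 4, and its value in this assay is estimated at 80000 nM, within a wide range from 10000 nM to 300000 nM, with a fair chance that only a limit is reported again.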

Compound 4, half-maximal effective concentration: 3000 nM
Compound 4: the middle estimate sits 27-fold (1.43 log units) above what was measured; measured number below the stated range.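

In this assay, the group on the aromatic carbon ortho to a large group turns out to matter: amino in place of nitro gives an at least 19-fold lower number from compound 3 to compound 4 (1.27 log units; beyond the scatter). The only earlier step altered a different part of the molecule and raised the number, so this is the first single change shown that lowers it, and it does so with the methyl of compound 3 still in place. Going by these compounds, the true size of the step stays unknown because compound 3 sits at a limit: the limit of > 57000 nM in this assay, at which 2 of the 4 values shown sit.

No property of nitro or amino is measured here, so what lies behind the step remains open. On these data alone, whether amino itself is special also remains open, and a hydroxyl, a methylamino or an acetamide on the same carbon would help to tell.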